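Bromo in Place of Iodo on the Shared Core

This account rests on a few compounds, and the source may have more. Where it says the series, first, only, none or still open, it means among the compounds named here.

Of the compounds shown here, three have so far been measured in an assay on isolated protein for inhibition of Calpain-1 catalytic subunit (Sus scrofa), read by FRET; a lower number here means a stronger inhibitor, a higher number a weaker inhibitor. Compound 1 `O=C(O)/C(S)=C/c1c[nH]c2c(F)cccc12` gives 120 nM. Compound 2 `O=C(O)/C(S)=C/c1c[nH]c2c(I)cccc12` gives 90 nM, the lowest of the three numbers, although its neighbour compound 1 sits within the scatter of it. Compound 3 `O=C(O)/C(S)=C/c1cccc(Br)c1`, which lacks the fused ring system of the other two, gives 4000 nM, and the gap between compound 2 and compound 3 lies well beyond the scatter. Within the data shown here, the single step measured so far between compounds that differ in one place, a 1.3-fold lower number from compound 1 to compound 2 (0.12 log units; within the scatter), exchanges one halogen for another on the shared core and stays within the scatter.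

Compound 4 `O=C(O)/C(S)=C/c1c[nH]c2c(Br)cccc12` has not yet been measured. It differs from compound 2 in one place: bromo in place of iodo on an aromatic carbon. Among the measured compounds shown here, the only step that bears on this change is a 1.3-fold lower number from compound 1 to compound 2 (0.12 log units; within the scatter), where a much larger halogen swap on the same carbon produced no difference beyond the scatter. A step of similar character, bromo for iodo, is therefore expected to give no change beyond the scatter in this assay. Compound 4 is expected to give about 100 nM, with a range from 50 nM to 200 nM. The expected step, a 1.1-fold higher number from compound 2 to compound 4 (0.05 log units; within the scatter), remains within the scatter.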

Compound 4, half-maximal inhibitory concentration: 2 nM
Compound 4: the middle estimate sits 50-fold (1.70 log units) above what was measured, and the stated range ends above it.
By their numbers in this assay, from the lowest: compound 4; then compounds 2 and 1 (each within the scatter of the next); then compound 3.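

In this assay the choice of halogen on this aromatic carbon turns out to matter a great deal: the step of a 45-fold lower number from compound 2 to compound 4 (1.65 log units; beyond the scatter) is large, and the step of a 60-fold lower number from compound 1 to compound 4 (1.78 log units; beyond the scatter) is large as well. The earlier swap of fluoro for iodo had suggested that this carbon was indifferent to which halogen it carries, but the three compounds do not follow a steady line from fluoro through bromo to iodo, since compounds 1 and 2 sit within the scatter of each other and only the bromo compound 4 stands apart. No measurement available here explains why bromo behaves so differently from the other two halogens.

The compounds shown leave open whether chloro, a methyl group or a methoxy group on this same carbon would keep a number as low as that of compound 4 or return to the level of compounds 1 and 2. They also leave open how the shared core behaves with a plain hydrogen on this carbon, and whether bromo on another carbon of the same six-membered ring would give a similar result.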